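A few compounds are considered here, and "the series" means these few. Any claim that something is new, unique, unknown or untested is made for them only; others in the source may bear on it.

Going by the values given here, compound 1 `O=C(O)c1cn(Cc2ccccc2)c2ccc([N+](=O)[O-])cc12` gives 65% in an assay on cells (Oocyte) for inhibition of pannexin-1 (Mus musculus), read by voltage clamp, tested at 50 uM, in the presence of a further agent that is not named here (a higher number here means more inhibition at the concentration tested (going by the name of the read-out), a lower number less inhibition), the highest of the two numbers measured so far. Compound 2 `O=C(O)c1ccc(Cn2cc(C(=O)O)c3cc([N+](=O)[O-])ccc32)cc1` gives 54%. The step of a number 11 percentage points lower from compound 1 to compound 2 (beyond the scatter) is a modest drop that goes with carboxy in place of hydrogen on an aromatic carbon. Compound 3 `O=C(O)c1cn(CCCc2ccccc2)c2ccc([N+](=O)[O-])cc12` differs from compound 1 by phenethyl in place of phenyl on a saturated chain carbon bound to an aromatic nitrogen. Among the compounds with values here, no measured step concerns a change of this kind, so nothing in the numbers points in either direction. The step expected here, no change at the digits printed from compound 1 to compound 3 (within the scatter), is none beyond the scatter. Compound 3 is therefore estimated at 65%, within 50% to 80%.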

Compound 3, a percentage reported as inhibition, at one concentration (the size of the read-out at that concentration, not a potency): 71%
Beside the measured number, compound 3's estimate is 6 percentage points below it; low and high end bracket the measured number.
By their numbers in this assay, from the lowest: compound 2; then compounds 1 and 3 (each within the scatter of the next).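

In this assay, the place on the saturated chain carbon bound to an aromatic nitrogen accepts phenethyl in place of phenyl with a number 6 percentage points higher from compound 1 to compound 3 (within the scatter), so the two groups cannot be told apart in this read-out. The earlier step changed the phenyl ring itself; this one shows that the link to the core can be lengthened without a change beyond the scatter. No measurement given here bears on the reason for this result. On these data alone, whether an amine or a longer chain at this same place would give a similar number remains open. So does whether carboxy on the ring of phenethyl would lower the number, as it did on the phenyl of compound 2.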